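The source may report more compounds than this note shows. Statements on the series, on what has been measured and on what is new or still open speak of the compounds shown alone.

Measured in a functional assay on MCF7 cells (Homo sapiens) for inhibition, read by resazurin assay, with a stated time of 72 h; a higher number here means a weaker inhibitor, a lower number a stronger inhibitor:
- compound 1 `CCOc1ccc(C2C(C3CC3)C(=O)N2c2cc(OC)c(OC)c(OC)c2)cc1`: 131 nM
- compound 2 `CCSc1ccc(C2CC(=O)N2c2cc(OC)c(OC)c(OC)c2)cc1`: 141 nM
- compound 3 `C=CC1C(=O)N(c2cc(OC)c(OC)c(OC)c2)C1c1ccc(OCC)cc1`: 14 nM

Compound 3, at 14 nM, holds the lowest number of the three in this assay, and both other compounds lie beyond the scatter from it. The next comparison is with compound 4 `CCOc1ccc(C2CC(=O)N2c2cc(OC)c(OC)c(OC)c2)cc1`, which has hydrogen in place of vinyl on a saturated ring carbon.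

Going by the values given here, only one measured step involves this ring carbon: a 9.4-fold lower number from compound 1 to compound 3 (0.97 log units; beyond the scatter), with vinyl in place of cyclopropyl. It shows that the group on this carbon can shift the number beyond the scatter, but it does not test hydrogen directly. Compound 2 has hydrogen on that ring carbon and gives 141 nM, yet it lacks the 4-ethoxyphenyl group of compound 4, so it serves only as a guide.

Taking these two observations together, removal of the vinyl is expected to give a higher number, beyond the scatter and of similar size to the measured step. The expected step is a 7.9-fold higher number from compound 3 to compound 4 (0.90 log units; beyond the scatter). For compound 4 the estimate is 110 nM, with an expected range from 35 nM to 350 nM.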

Compound 4, half-maximal inhibitory concentration: 64 nM
Beside the measured number, compound 4's estimate is 1.7-fold (0.24 log units) above it; measured number inside the range.
By their numbers in this assay, from the lowest: compound 3; then compound 4; then compounds 1 and 2 (each within the scatter of the next).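

In this assay, compound 4 gives this ring carbon a direct hydrogen reference, and the two groups tested there fall on opposite sides of it: removing vinyl raises the number (a 4.6-fold higher number from compound 3 to compound 4 (0.66 log units; beyond the scatter)), while removing cyclopropyl lowers it (a 2.0-fold lower number from compound 1 to compound 4 (0.31 log units; beyond the scatter)). The group on this carbon therefore does not act in one direction across these compounds, and vinyl is the only one of the two that improves on hydrogen, with cyclopropyl giving the weaker inhibitor. With hydrogen held on the ring carbon, the aromatic substituent also has a small but readable effect, with ethoxy in place of ethylsulfanyl on an aromatic carbon lowering the number (a 2.2-fold lower number from compound 2 to compound 4 (0.34 log units; beyond the scatter)).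

Still open, from the compounds shown here alone, is where ethyl, ethynyl or an aminomethyl group on this ring carbon would stand against hydrogen and vinyl, and whether vinyl would give a step of similar size with ethylsulfanyl on the aromatic carbon. No accompanying measurement bears on what lies behind these steps.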